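Changing the benzyl group on a shared core

The compounds below may be only part of what the source reports. "The series", "measured", "known", "first", "only" and "open" are said of these compounds alone.

The compounds here share one core and differ only in the group attached to the amine nitrogen in the ring. Going by the values given here, compound 1 `O=c1c2cnn(-c3ccc(F)cc3)c2ncn1CC1(O)CCN(Cc2ccc(Br)cc2)CC1` is the only one with a number: in an assay on Sf21 cells for inhibition of ubiquitin carboxyl-terminal hydrolase 7 (Homo sapiens), read by spectrophotometry, with stated times of 30 min and 2 h (on this read-out lower numbers stand for stronger inhibition and higher numbers for weaker inhibition), compound 1 gives 6700 nM. Compound 2 `N#Cc1ccc(CN2CCC(O)(Cn3cnc4c(cnn4-c4ccc(F)cc4)c3=O)CC2)cc1` has no result in this assay; the entry is recorded as "not determined" (no result reported). Among the compounds with values here, compound 3 `Cc1ccccc1CN1CCC(O)(Cn2cnc3c(cnn3-c3ccc(F)cc3)c2=O)CC1` stands in the same position: in this assay compound 3 also has no single number, its entry being recorded as "not determined" (no result reported), so no step between measured compounds can be drawn from it, and compound 2 is the one further entry without a number.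

Compound 4 `N#Cc1cc(Cl)ccc1CN1CCC(O)(Cn2cnc3c(cnn3-c3ccc(F)cc3)c2=O)CC1` is the next step. Compared with compound 3, the change is 4-chloro-2-cyanophenyl in place of 2-methylphenyl on a saturated chain carbon bound to an amine nitrogen in a ring, that is, a 4-chloro-2-cyanophenyl group in place of a 2-methylphenyl group on a saturated chain carbon bound to an amine nitrogen in a ring. Within the data shown here, with no measured step to lean on, no direction is expected beyond the usual scatter, and the only anchor is compound 1 with 6700 nM. On that basis compound 4 is expected to give about 6000 nM in this assay, with a plausible range from 1500 nM to 25000 nM.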

Compound 4, half-maximal inhibitory concentration: 11400 nM
For compound 4 the middle estimate is 1.9-fold (0.28 log units) below the measured one, within the range that was stated.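

Compound 4 gives this position on the shared core its first readable comparison in this assay, as the other compound with a number is compound 1. The comparison shows a 1.7-fold higher number from compound 1 to compound 4 (0.23 log units; within the scatter), with 4-chloro-2-cyanophenyl in place of 4-bromophenyl on a saturated chain carbon bound to an amine nitrogen in a ring. Two differently substituted phenyl groups, one carrying a bromine and the other a chlorine and a nitrile, therefore cannot be told apart on this read-out, and no supporting measurement bears on this result.

Steps involving compound 2 and compound 3 cannot be read, so the effect of the groups on those compounds remains unknown, including how the 2-methylphenyl group of compound 3 compares with the 4-chloro-2-cyanophenyl group of compound 4. Also open, on these data alone, is whether a clearly stronger or weaker result would come from a carboxylic acid or an amine on the phenyl ring, or from a pyridine in place of the phenyl ring.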